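The source may report more compounds than this note shows. Statements on the series, on what has been measured and on what is new or still open speak of the compounds shown alone.

Measured in a functional assay on Coronary artery (Bos taurus); on this read-out lower numbers stand for an effect already at smaller amounts and higher numbers for an effect only at larger amounts of compound:
- compound 1 `CCCCCNC(=O)NCCCC/C=C\CCCCCS(=O)(=O)c1ccccc1O`: 5000 nM
- compound 2 `CCCCCNC(=O)NCCCC/C=C\CCCCCSc1nnn[nH]1`: 3700 nM

Compound 2, at 3700 nM, stands within the scatter of compound 1, at 5000 nM, so the two numbers give no order.

The next compound to be measured is compound 3 `CCCCCNC(=O)NCCCC/C=C\CCCCCS(=O)(=O)c1ncn[nH]1`. Its difference from compound 2 is a group of 8 heavy atoms (2 carbon, 3 nitrogen, 2 oxygen, 1 sulfur; one five-membered aromatic ring with 3 hetero atoms) in place of a group of 6 heavy atoms (1 carbon, 4 nitrogen, 1 sulfur; one five-membered aromatic ring with 4 hetero atoms), on a saturated chain carbon, five bonds along the chain from a double-bonded chain carbon.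

Within the data shown here, only one measured step bears on this change, and it also exchanged the group on a saturated chain carbon, five bonds along the chain from a double-bonded chain carbon: a 1.4-fold lower number from compound 1 to compound 2 (0.13 log units; within the scatter). That step lies within the scatter. A step of similar size is therefore expected here, with no clear direction and nothing beyond the scatter in this assay. Among the measured compounds shown here, this expectation is weakly grounded, as it rests on a single step and no measured compound carries the entering group.

The estimated step is small: a 1.1-fold higher number from compound 2 to compound 3 (0.03 log units; within the scatter).

Compound 3 is expected at 4000 nM, with an estimated range of 1500 nM to 10000 nM.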

Compound 3, half-maximal effective concentration: 3100 nM
The estimate for compound 3 lay 1.3-fold (0.11 log units) above the measured number; low and high end bracket the measured number.
By their numbers in this assay, from the lowest: compounds 3, 2 and 1 (each within the scatter of the next).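

In this assay, the exchange of the (1H-tetrazol-5-yl)sulfanyl group for the sulfonyl-linked 1H-1,2,4-triazol-5-yl group on the saturated chain carbon, five bonds along the chain from a double-bonded chain carbon, gives a 1.2-fold lower number from compound 2 to compound 3 (0.08 log units; within the scatter), so even this exchange of both ring and sulfur oxidation state leaves the two compounds undistinguished. With the sulfonyl retained in both compounds, 1H-1,2,4-triazol-5-yl in place of 2-hydroxyphenyl on the sulfonyl sulfur gives a 1.6-fold lower number from compound 1 to compound 3 (0.21 log units; within the scatter), which extends the comparison to an exchange of the group on that sulfur alone and again yields no order, so the three groups compared at this position cannot be separated on this read-out. No supporting data are available that could explain these small differences.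

Going by these compounds, it remains open whether any group at this position can move the number beyond the scatter, for example a carboxylic acid or an amine on the same saturated chain carbon. On these data alone, all three compounds also share the same core, so the contribution of the rest of the molecule, such as a longer chain in place of the pentyl group, stays untested here.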